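The source may report more compounds than this note shows. Statements on the series, on what has been measured and on what is new or still open speak of the compounds shown alone.

Measured compounds: compound 1 `C[C@]1(CN2CCc3nc(N4CCC(F)(F)CC4)ccc3C2)Cn2cc([N+](=O)[O-])nc2O1`; compound 2 `C[C@]1(CN2CCc3nc(-c4cc(F)ccc4F)ccc3C2)Cn2cc([N+](=O)[O-])nc2O1`.

Compound 1 has no reported result in an ADME assay on Vero cells (Chlorocebus sabaeus) for cytotoxicity, read by MTT assay, with a stated time of 72 h (a higher number here means that more compound is tolerated, a lower number that less compound is tolerated), "not determined" (no result reported). Compound 2 gives only a limit in this assay, namely > 32 ug/mL, so compound 2 sits at the limit of > 32 ug/mL in this assay, at which 1 of the 2 values shown sits. Compound 3 `C[C@]1(CN2CCc3nc(-c4ccc(Cl)cc4F)ccc3C2)Cn2cc([N+](=O)[O-])nc2O1` differs from compound 2 by 4-chloro-2-fluorophenyl in place of 2,5-difluorophenyl on an aromatic carbon. Within the data shown here, no measured step covers such a change, and the account expects none beyond the scatter in this assay, with the same limit the likeliest outcome. Compound 3 is therefore estimated at 32 ug/mL, between 16 ug/mL and 64 ug/mL, an expected step of a number no higher from compound 2 to compound 3 (the limit leaves the size open).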

Compound 3, half-maximal cytotoxic concentration: > 32 ug/mL
Compound 3 was reported as a limit; the forecaster's own chance of this, stated with the estimate: 80%; the middle value lies on the limit itself.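

In this assay, compound 2 and compound 3 are both reported only as limits, so no step can be read between them. The compounds shown leave open how much compound either tolerates and whether 4-chloro-2-fluorophenyl in place of 2,5-difluorophenyl changes that at all.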